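The compounds below may be only part of what the source reports. "The series", "measured", "known", "first", "only" and "open" are said of these compounds alone.

Compound 1 `CC1(C)C2CCC1(C)C(OC(=O)/C=C/c1ccc(O)c(O)c1[N+](=O)[O-])C2`: 52900 nM
Compound 2 `O=C(/C=C/c1cc(O)c(O)c([N+](=O)[O-])c1)OCCc1ccccc1`: 11400 nM

Both compounds were tested in a functional assay on A549 cells (Homo sapiens) for cytotoxicity, read by MTT assay; on this read-out higher numbers stand for weaker inhibition and lower numbers for stronger inhibition. Compound 2, at 11400 nM, has the lower of the two numbers and so shows the stronger inhibition. Compound 1 gives 52900 nM, and the gap between the two lies beyond the usual scatter of repeated measurements.

The next compound to be tested is compound 3 `COc1cc(/C=C/C(=O)OCCc2ccccc2)cc([N+](=O)[O-])c1O`, which keeps the rest of compound 2 unchanged. The single difference is methyl in place of hydrogen on an oxygen on an aromatic ring, or hydroxy to methoxy.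

For the measured compounds named here, no measured pair here shows this change, and the two measured compounds differ in more than one place, so the data give no direct guide to its size. The forecast therefore starts from compound 2 at 11400 nM and stays loose. A modest move toward a higher number, meaning weaker inhibition, seems the likeliest outcome, although no real change is also possible. The expected move is a 1.8-fold higher number from compound 2 to compound 3 (0.24 log units; within the scatter). For compound 3 the estimated value is 20000 nM, with an expected range from 8000 nM to 55000 nM.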

Compound 3, half-maximal inhibitory concentration: > 300000 nM
Compound 3: only a limit was reported (the forecaster's own chance of this, stated with the estimate: 4%); middle value at least 15-fold (1.17 log units) from the limit.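

In this assay compound 3 gives > 300000 nM, and this figure is a limit of the assay, not a measured number. Compound 2 and compound 3 differ in one place only, so this pair isolates a single change, which compound 1 and compound 2 could not do: methyl in place of hydrogen on an oxygen on an aromatic ring, or hydroxy to methoxy, gives an at least 26-fold higher number from compound 2 to compound 3 (1.42 log units; beyond the scatter). This one added carbon on that oxygen is therefore enough to move the number far beyond the scatter toward weaker inhibition, and the true size of the step remains unknown, since only its lower bound can be read: the limit of > 300000 nM in this assay, at which 1 of the 3 values shown sits.

The compounds shown leave open whether other groups on the same oxygen, such as an ethyl or an acetyl, or an amine in place of the hydroxy, would act as the methyl does. They also leave open whether the same change would have a similar effect on the core of compound 1, or at the other hydroxy on the ring of compound 2.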